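Solubility of oxazole piperidine amides: aryl swap on the core

This account rests on a few compounds, and the source may have more. Where it says the series, first, only, none or still open, it means among the compounds named here.

Measured so far in a physicochemical assay for solubility, in phosphate buffer, measured as kinetic solubility, at pH 7.4; a higher number here means a more soluble compound, a lower number a less soluble compound:
- compound 1, `Cc1oc(-c2ccc(Cl)cc2)nc1CN1CCC(C(=O)NCCCN2C[C@H](C)C[C@H](C)C2)CC1`: > 72 ug/mL
- compound 2, `Cc1ccccc1-c1nc(CN2CCC(C(=O)NCCCN3[C@H](C)CCC[C@@H]3C)CC2)c(C)o1`: > 69 ug/mL
- compound 3, `Cc1ccccc1-c1nc(CN2CCC(C(=O)NCCCN3CC4CCCC(C4)C3)CC2)c(C)o1`: > 71 ug/mL

Each of these values is a limit of this assay and not a number. For compound 1 the value > 72 ug/mL is such a limit; it stands at the limit of > 72 ug/mL in this assay, at which 1 of the 3 values shown sits. The other two values are limits as well, at the limit of > 69 ug/mL in this assay, at which 1 of the 3 values shown sits, and at the limit of > 71 ug/mL in this assay, at which 1 of the 3 values shown sits. Compound 1 therefore cannot be placed above or below compound 2 or compound 3 on the numbers shown.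

Among the compounds with values here, the one measured step, a step that the two limits leave unreadable from compound 2 to compound 3, changes the group on the saturated chain carbon three bonds along the chain from the amide-type nitrogen; its size is not readable because both ends sit at limits.

Compound 4, `Cc1ccc(-c2nc(CN3CCC(C(=O)NCCCN4C[C@H](C)C[C@H](C)C4)CC3)c(C)o2)c(C)c1`, differs from compound 1 as follows: 2,4-dimethylphenyl in place of 4-chlorophenyl on an aromatic carbon. Within the data shown here, no measured step touches this aromatic carbon of the core, so nothing here gives the size or direction of the change in this assay. Given that compound 1 sits at a limit, > 72 ug/mL, the expectation is that compound 4 also lands at or near the limit, with an expected step of an at least 1.0-fold lower number from compound 1 to compound 4 (0.01 log units; that floor lies within the scatter). Compound 4 is expected to show 70 ug/mL, within 30 ug/mL to 150 ug/mL.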

Compound 4, solubility: > 71 ug/mL
Compound 4: only a limit was reported; the forecaster's own chance of this, stated with the estimate: 65%; at least 1.0-fold (0.00 log units) between middle value and limit.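

In this assay, within the data shown here, compound 1 and compound 4 both stand at limits of the assay and not at numbers, and no step between them can be read. The compounds shown leave open how far any of these values lies beyond its limit, and whether 2,4-dimethylphenyl in place of 4-chlorophenyl shifts the read-out at all.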